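The source may hold more compounds than are shown below. What is called first, only, known or untested is meant among the compounds shown, and "the series" means these compounds.

Measured so far in a functional assay, read by Griess assay, with a stated time of 150 min, tested at 75 ug/mL; on this read-out lower numbers stand for a weaker effect and higher numbers for a stronger effect at the one concentration tested:

Compound 1 `O=S(=O)(CC1=NCCS1)C1C(c2ccccc2)=NOC1c1ccccc1`: "not active" (no number reported)
Compound 2 `COc1ccc(C2=NOC(c3ccc(C)cc3)C2S(=O)(=O)CC2=NCCO2)cc1`: 65.9%
Compound 3 `COc1ccc(C2=NOC(c3ccc(C)cc3)C2S(=O)(=O)CC2=NCCS2)cc1`: 54.1%

Compound 1 carries no number in this assay, only the report that it was not active. The difference between the core of compound 1 and the shared core of compounds 2 and 3 is not broken down here.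

Within the pair of compounds 2 and 3 the single change is a group of 5 heavy atoms (3 carbon, 1 nitrogen, 1 oxygen; one five-membered non-aromatic ring with 2 hetero atoms) in place of a group of 5 heavy atoms (3 carbon, 1 nitrogen, 1 sulfur; one five-membered non-aromatic ring with 2 hetero atoms), on a saturated chain carbon bound to a sulfonyl sulfur, and that change gave a number 11.8 percentage points higher from compound 3 to compound 2 (beyond the scatter).

Compound 4 `O=S(=O)(CC1=NCCO1)C1C(c2ccccc2)=NOC1c1ccccc1` is yet to be measured. It arises from compound 1 by a group of 5 heavy atoms (3 carbon, 1 nitrogen, 1 oxygen; one five-membered non-aromatic ring with 2 hetero atoms) in place of a group of 5 heavy atoms (3 carbon, 1 nitrogen, 1 sulfur; one five-membered non-aromatic ring with 2 hetero atoms), on a saturated chain carbon bound to a sulfonyl sulfur, the same change as in the measured pair. Within the data shown here, compound 4 is expected to gain a step of a similar size to the one from compound 3 to compound 2, but starting from an inactive parent. Compound 4 is therefore estimated at 15%, within 0% to 35%.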

Compound 4, a percentage reported as activity, at one concentration (the size of the read-out at that concentration, not a potency): 57.2%
Compound 4: the middle estimate sits 42.2 percentage points below what was measured; the measured number lies above the stated range.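

In this assay, among these compounds, compound 1 gives "not active" (no number reported) and compound 4 gives 57.2% so no step between them can be read. The compounds shown leave open how large this ring exchange is on the core of compound 1, and no measured evidence bears on the result.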